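A few compounds are considered here, and "the series" means these few. Any claim that something is new, unique, unknown or untested is made for them only; others in the source may bear on it.

Three compounds share one core and differ only in the group on a carbonyl carbon. In an assay on isolated protein for inhibition of Nitric oxide synthase, inducible (Homo sapiens), read by scintillation counting, with a stated time of 30 min, tested at 50 uM (on this read-out higher numbers stand for more inhibition at the one concentration tested (going by the name of the read-out) and lower numbers for less inhibition), compound 1 `CC1(C)SC(c2ccccc2N)=NN1C(=O)c1ccccc1` gives 39.8%, compound 2 `CCCC(=O)N1N=C(c2ccccc2N)SC1(C)C` gives 35.2%, and compound 3 `CC1(C)SC(c2ccccc2N)=NN1C(=O)C1CCC1` gives 46.9%, the highest of the three numbers. Going by the values given here, the only step beyond the scatter is a number 11.7 percentage points higher from compound 2 to compound 3 (beyond the scatter), while a number 7.1 percentage points higher from compound 1 to compound 3 (within the scatter) stays within it. Compound 4 `CC1(C)SC(c2ccccc2N)=NN1C(=O)C1CCCCC1` carries the change (cyclohexyl in place of cyclobutyl on a carbonyl carbon). Among the compounds with values here, no measured step enlarges a ring on that carbon, so the two steps above give only loose guidance, and the expected step in this assay is a number 1.9 percentage points lower from compound 3 to compound 4 (within the scatter), not beyond the scatter. Compound 4 is therefore estimated at 45%, with a likely range from 30% to 60%.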

Compound 4, a percentage reported as inhibition, at one concentration (the size of the read-out at that concentration, not a potency): 28%
Compound 4: middle estimate off by 17 percentage points, on the high side, outside the stated range (below it).
By their numbers in this assay, from the lowest: compounds 4, 2, 1 and 3 (each within the scatter of the next, the first and the last beyond it).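

In this assay ring size on the carbonyl carbon proves to matter, since going from cyclobutyl to cyclohexyl gives a number 18.9 percentage points lower from compound 3 to compound 4 (beyond the scatter) and these two carbon rings are not interchangeable here. Measured against phenyl, cyclohexyl gives a number 11.8 percentage points lower from compound 1 to compound 4 (beyond the scatter), whereas against propyl it gives a number 7.2 percentage points lower from compound 2 to compound 4 (within the scatter). No evidence at hand bears on this result. A cyclopentyl ring on this carbon would show whether the numbers fall gradually with ring size or abruptly. On these data alone, how a piperidine ring, which carries a nitrogen, would read also stays open.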